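Propyl to isopropyl on the side chain: working notes

The source may hold more compounds than are shown below. What is called first, only, known or untested is meant among the compounds shown, and "the series" means these compounds.

In a functional assay on HeLa cells (Homo sapiens) for antiproliferative activity, read by MTT assay, with a stated time of 72 h (a higher number here means a weaker inhibitor, a lower number a stronger inhibitor), compound 1 (`COc1ccc(Nc2nc3c(c(Oc4cccc(NC(=O)/C=C/C(C)C)c4)n2)CSCC3)cc1`) gives 22900 nM and compound 2 (`CCC/C=C/C(=O)Nc1cccc(Oc2nc(Nc3ccc(OC)nc3)nc3c2CSCC3)c1`) gives 15300 nM. Among the compounds with values here, these two values lie within the scatter of each other, so compound 2 stands level with the only other measured compound. Compound 3 (`COc1ccc(Nc2nc3c(c(Oc4cccc(NC(=O)/C=C/C(C)C)c4)n2)CSCC3)cn1`) departs from compound 2 in one place: isopropyl in place of propyl on a double-bonded chain carbon bound to a double-bonded chain carbon. This puts isopropyl in place of propyl on a double-bonded chain carbon bound to a double-bonded chain carbon. Within the data shown here, no measured pair isolates this change, so its size is not known directly. Compound 2 has the propyl and differs elsewhere too from the isopropyl-bearing compound 1, yet the two stay within the scatter of each other, with compound 1 at 22900 nM, so no shift beyond the scatter is expected in this assay, in either direction. The expected step is a 1.2-fold higher number from compound 2 to compound 3 (0.07 log units; within the scatter). For compound 3 the estimated value is 18000 nM, with an expected range of 8000 nM to 40000 nM.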

Compound 3, half-maximal inhibitory concentration: 27800 nM
Compound 3: middle estimate off by 1.5-fold (0.19 log units), on the low side; low and high end bracket the measured number.
By their numbers in this assay, from the lowest: compounds 2, 1 and 3 (each within the scatter of the next).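

In this assay, the direct step is a 1.8-fold higher number from compound 2 to compound 3 (0.26 log units; within the scatter), so on a double-bonded chain carbon bound to a double-bonded chain carbon, isopropyl and propyl are not told apart. The second single change, 6-methoxypyridin-3-yl in place of 4-methoxyphenyl on a nitrogen on an aromatic ring, gives a 1.2-fold higher number from compound 1 to compound 3 (0.08 log units; within the scatter) and is likewise not resolved from the scatter. Nothing available bears on either result.

As far as these compounds go, whether an amine, a carboxylic acid or a longer chain in place of propyl or isopropyl at this place would give a step beyond the scatter remains open. Also open, from the compounds shown here alone, is whether a group other than 6-methoxypyridin-3-yl or 4-methoxyphenyl, such as a morpholine-bearing phenyl, on a nitrogen on an aromatic ring would do so.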